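The source may report more compounds than this note shows. Statements on the series, on what has been measured and on what is new or still open speak of the compounds shown alone.

Compound 1 `CCOC(=O)c1c(-c2cccc(OC(F)(F)F)c2)[nH]c2cc(OC)ccc2c1=O`: > 22000 nM, a limit
Compound 2 `CCOC(=O)c1c(-c2cccc(OC)c2)[nH]c2cc(OC(F)(F)F)ccc2c1=O`: > 22000 nM, a limit

Both entries come from an ADME assay on HEK293 cells (Homo sapiens) for cytotoxicity, read by luminescence, with a stated time of 72 h; a lower number here means that less compound is needed, a higher number that more compound is needed for the effect. In this assay compound 2 gives > 22000 nM, which is a limit and not a number. Compound 2 therefore has no exact position on the scale, and neither does compound 1. The whole record so far is the limit of > 22000 nM in this assay, at which 2 of the 2 values shown sit.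

Compound 3 `CCOC(=O)c1c(-c2cccc(OC(F)(F)F)c2)[nH]c2cc(OC(F)(F)F)ccc2c1=O` is the next compound to consider. It differs from compound 2 in one place: trifluoromethyl in place of methyl on an oxygen on an aromatic ring. This is trifluoromethyl in place of methyl on an oxygen on an aromatic ring, or methoxy to trifluoromethoxy. Compound 1 and compound 2 each carry one methoxy and one trifluoromethoxy, while compound 3 has no methoxy left.

For the measured compounds named here, no measured step between two compounds is available as a guide. The expectation rests on compound 2 and its limit of > 22000 nM. The expected change, a number no higher from compound 2 to compound 3 (the limit leaves the size open), is none beyond the scatter, in either direction. For compound 3 the estimated value is 22000 nM, with an expected range from 11000 nM to 44000 nM.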

Compound 3, half-maximal effective concentration: > 22000 nM
Compound 3 was reported as a limit; the forecaster's own chance of this, stated with the estimate: 80%; the middle value sits exactly at the limit.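

In this assay compound 3 gives > 22000 nM, which is a limit and not a number. The steps to compound 3 from compound 1 and from compound 2 cannot be read, as every value is a limit: the limit of > 22000 nM in this assay, at which 3 of the 3 values shown sit. Left open is whether methoxy to trifluoromethoxy changes the result in this assay at all, and how much of compound 1, compound 2 or compound 3 gives the effect.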